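A few compounds are considered here, and "the series" means these few. Any claim that something is new, unique, unknown or untested is made for them only; others in the source may bear on it.

In a toxicity assay on Vero cells (Chlorocebus sabaeus) for cytotoxicity (a higher number here means that more compound is tolerated, a lower number that less compound is tolerated), three compounds have been measured so far:

Compound 1 `COc1nc(C(C)(C)C)ccc1[C@@H](c1ccccc1)[C@@](O)(CCN(C)C)c1cccc2ccccc12`: 27.6 ug/mL
Compound 2 `COc1nc(C2CCCCC2)ccc1[C@@H](c1ccccc1)[C@@](O)(CCN(C)C)c1cccc2ccccc12`: 32.3 ug/mL
Compound 3 `COc1nc(-c2ccsc2)ccc1[C@@H](c1ccccc1)[C@@](O)(CCN(C)C)c1cccc2ccccc12`: 24.4 ug/mL

Compound 3, at 24.4 ug/mL, cannot be told apart from the other two, since its steps to both lie within the scatter. The next compound, compound 4 `COc1nc(-c2ccc(C#N)cc2)ccc1[C@@H](c1ccccc1)[C@@](O)(CCN(C)C)c1cccc2ccccc12`, keeps the shared core and differs from compound 3 in one group: 4-cyanophenyl in place of thiophen-3-yl on an aromatic carbon. Here 4-cyanophenyl takes the place of thiophen-3-yl on an aromatic carbon.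

Going by the values given here, no measured step makes this exact exchange, and no measured compound carries a nitrile, so the data offer no direct test. Among the compounds with values here, three steps bear on it indirectly, as each exchanges the group at this same place: a 1.2-fold higher number from compound 1 to compound 2 (0.07 log units; within the scatter), a 1.1-fold lower number from compound 1 to compound 3 (0.05 log units; within the scatter) and a 1.3-fold lower number from compound 2 to compound 3 (0.12 log units; within the scatter). Among tert-butyl, cyclohexyl and thiophen-3-yl, then, nothing has moved beyond the scatter in this assay. On that basis, no step beyond the scatter is expected for the new group, and no direction is favoured. The expected step is a 1.0-fold higher number from compound 3 to compound 4 (0.01 log units; within the scatter). For compound 4 the estimated value is 25 ug/mL, with an expected range from 14 ug/mL to 42 ug/mL.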

Compound 4, half-maximal cytotoxic concentration: > 50 ug/mL
Compound 4: no number, only a limit; the forecaster's own chance of this, stated with the estimate: 3%; at least 2.0-fold (0.30 log units) between middle value and limit.
By their numbers in this assay, from the lowest: compounds 3, 1 and 2 (each within the scatter of the next). At a limit, above all of these: compound 4.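

The result for compound 4 in this assay is a limit of the assay and not a number: the limit of > 50 ug/mL in this assay, at which 1 of the 4 values shown sits.

Among tert-butyl, cyclohexyl and thiophen-3-yl, this position on an aromatic carbon next to the ring nitrogen had shown nothing beyond the scatter, yet 4-cyanophenyl in place of thiophen-3-yl gives an at least 2.0-fold higher number from compound 3 to compound 4 (0.31 log units; beyond the scatter), so the read-out here does respond to the group that is placed there. The comparisons with the other two compounds are less firm, at an at least 1.5-fold higher number from compound 2 to compound 4 (0.18 log units; that floor lies within the scatter) and an at least 1.8-fold higher number from compound 1 to compound 4 (0.25 log units; that floor lies within the scatter), and these two steps cannot be read as true separations.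

Compound 4 brings a six-membered aromatic ring of carbon only and a nitrile together, so the compounds shown do not tell which of the two goes with the step, nor how large the step really is. A plain phenyl group at this place would separate the ring from the nitrile, and an amine or a carboxylic acid on that phenyl ring would show whether groups other than the nitrile give a similar result.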